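Thiosemicarbazide series: substitution on the terminal amide-type nitrogen

The compounds below may be only part of what the source reports. "The series", "measured", "known", "first", "only" and "open" are said of these compounds alone.

The series shares the core of compound 1 `CC1=CC[C@@H]([C@@](C)(O)CCCC(C)(C)NC=S)CC1` and varies only at the thiocarbonyl carbon and the nitrogen attached to it. In a functional assay on K562 cells (Homo sapiens) for cytotoxicity, read by sulforhodamine B assay (on this read-out higher numbers stand for lower toxicity in this test and lower numbers for higher toxicity in this test), compound 1 gives > 100000 nM, which is a limit of the assay and not a number (the limit of > 100000 nM in this assay, at which 1 of the 3 values shown sits). Compound 2 `CC1=CC[C@@H]([C@@](C)(O)CCCC(C)(C)NC(=S)NN)CC1` carries aminoamino in place of hydrogen on the thiocarbonyl carbon, and in this assay compound 2 gives 9580 nM. Going by the values given here, the step of an at least 10-fold lower number from compound 1 to compound 2 (1.01 log units; beyond the scatter) is the only measured step in the set. Compound 3 `CC1=CC[C@@H]([C@@](C)(O)CCCC(C)(C)NC(=S)N/N=C\c2cccc([N+](=O)[O-])c2)CC1`, with a larger group on the same nitrogen, in this assay gives 12600 nM. Compound 2 therefore holds the lowest of the two numbers that are not limits, and compound 3 sits within the scatter of it. The next compound, compound 4 `CC1=CC[C@@H]([C@@](C)(O)CCCC(C)(C)NC(=S)N/N=C(/C)c2ccccc2)CC1`, differs from compound 2 by a group of 9 heavy atoms (8 carbon, 1 nitrogen; one six-membered aromatic ring of carbon only) in place of one nitrogen atom, on an amide-type nitrogen. Among the compounds with values here, no measured step covers this change. The values of compound 2 and compound 3 show that a group of similar build on this nitrogen leaves the number within the scatter, so in this assay no step beyond the scatter is expected, in either direction. The expected step of a 1.0-fold higher number from compound 2 to compound 4 (0.02 log units; within the scatter) is accordingly small. Compound 4 is estimated at 10000 nM, with a range from 3000 nM to 35000 nM.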

Compound 4, concentration lethal to 50% of the cells: 1540 nM
Compound 4: the middle estimate sits 6.5-fold (0.81 log units) above what was measured; the measured number lies below the stated range.
By their numbers in this assay, from the lowest: compound 4; then compounds 2 and 3 (each within the scatter of the next). At a limit, above all of these: compound 1.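

Within the thiosemicarbazide series, the amide-type nitrogen on the thiocarbonyl carbon proves able to move the number in this assay: the replacement of amino by the aromatic group gives a 6.2-fold lower number from compound 2 to compound 4 (0.79 log units; beyond the scatter), the first step beyond the scatter at this nitrogen. Compound 3 also carries a large aromatic group on this nitrogen yet stays within the scatter of compound 2, so among these compounds the presence of a large group alone does not set the number, and the outcome depends on how the group is built, with a nitro group in compound 3 and a methyl group with an unsubstituted phenyl ring in compound 4. Nothing among the data shown accounts for this step.

On these data alone, whether the methyl group, the missing nitro group or both separate compound 4 from compound 3 remains open, and a compound with a hydrogen in place of that methyl group, or with a longer chain such as ethyl, would help to decide it. Also open, as far as these compounds go, is whether the aromatic ring is required at all, which a cyclohexyl group in its place would test, and whether an amine or a carboxylic acid on that ring would keep the number of compound 4.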